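This account rests on a few compounds, and the source may have more. Where it says the series, first, only, none or still open, it means among the compounds named here.

This account follows the step from compound 3 `O=C(Nc1ccc(Cl)c(-c2nc3ccccc3s2)c1)c1cc([N+](=O)[O-])ccc1Cl` to compound 4 `O=C(Nc1ccc(Cl)c(C(F)(F)F)c1)c1cc([N+](=O)[O-])ccc1Cl` in an ADME assay for permeability, using PAMPA, at pH 7.4; a lower number here means that the compound crosses the layer more slowly, a higher number that the compound crosses the layer faster. Of the compounds shown here, three have been measured there so far. Compound 1 `O=C(Nc1ccc(O)c(-c2nc3ccccc3s2)c1)c1cc([N+](=O)[O-])ccc1Cl` gives "below limit of detection" (no number reported) in this assay, so no number is reported for it. Compound 2 `O=C(Nc1ccc(F)c(-c2nc3ccccc3s2)c1)c1cc([N+](=O)[O-])ccc1Cl` gives 17 10^-6 cm/s in this assay. Compound 3 gives 3 10^-6 cm/s in this assay, the lowest of the two numbers, and its nearest neighbour is reached by the step of a 5.7-fold lower number from compound 2 to compound 3 (0.75 log units; beyond the scatter), which is beyond the scatter. Compound 4 differs from compound 3 by trifluoromethyl in place of 1,3-benzothiazol-2-yl on an aromatic carbon. Among the measured compounds shown here, the only measured step, a 5.7-fold lower number from compound 2 to compound 3 (0.75 log units; beyond the scatter), is a chloro in place of fluoro on an aromatic carbon and leaves the 1,3-benzothiazol-2-yl group untouched, so no measured step bears directly on the present change, and the data give no direction for it. In the absence of such guidance, the expected step of a 1.7-fold higher number from compound 3 to compound 4 (0.22 log units; within the scatter) is kept small, close to the scatter, with wide uncertainty on both sides. Compound 4 is therefore estimated to give 5 10^-6 cm/s in this assay, with a range from 1.5 10^-6 cm/s to 15 10^-6 cm/s.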

Compound 4, apparent permeability: 8 10^-6 cm/s
The estimate for compound 4 lay 1.6-fold (0.20 log units) below the measured number, and the stated range covers the measured number.
By their numbers in this assay, from the lowest: compound 3; then compound 4; then compound 2.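

In this assay, among the compounds shown here, the step is a 2.7-fold higher number from compound 3 to compound 4 (0.43 log units; beyond the scatter) and gives the first reading for a change at this position, on an aromatic carbon ortho to a chloro group, since the earlier step between measured compounds left the 1,3-benzothiazol-2-yl group in place. It shows that this group, with its two aromatic rings, can give way to trifluoromethyl, a smaller group with no ring, while the compound keeps a reported number and that number moves upward by more than the scatter. The results shown offer no measurement that would explain this rise, so its origin stays unassigned.

With only one replacement at this position, the compounds shown cannot tell whether the rise belongs to trifluoromethyl itself or would appear with any group in place of 1,3-benzothiazol-2-yl, and a methyl, a nitrile, an amine or a carboxylic acid at the same carbon could begin to separate these readings. From the compounds shown here alone, it also remains open whether the step would keep its direction and size with fluoro in place of the chloro group.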